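Hydroxymethyl on the furan analog of the shared core

A few compounds are considered here, and "the series" means these few. Any claim that something is new, unique, unknown or untested is made for them only; others in the source may bear on it.

Compound 3 `Nc1nc(-c2ccccc2)nc2sc(-c3ccco3)nc12` stands in a functional assay on CHO cells for antagonist activity at adenosine receptor A2b (Homo sapiens), read by cAMP accumulation, with a stated time of 10 min (a higher number here means a weaker inhibitor, a lower number a stronger inhibitor), only at a limit. In this assay compound 3 gives > 30000 nM, a limit of the assay and not a number. Compound 1 `Nc1nc(-c2ccccc2)nc2sc(-c3ccccc3)nc12` gives in this assay > 30000 nM, likewise a limit. Compound 2 `Nc1nc(-c2ccc(CO)cc2)nc2sc(-c3ccccc3)nc12` gives > 30000 nM, also a limit. All three values therefore sit at the limit of > 30000 nM in this assay, at which 3 of the 3 values shown sit, so the steps a step that the two limits leave unreadable from compound 1 to compound 3 and a step that the two limits leave unreadable from compound 1 to compound 2 cannot be sized. Compound 4 `Nc1nc(-c2ccc(CO)cc2)nc2sc(-c3ccco3)nc12` differs from compound 3 by hydroxymethyl in place of hydrogen on an aromatic carbon. Among the measured compounds shown here, the only comparable step, a step that the two limits leave unreadable from compound 1 to compound 2, carries the same change between two limits, so no readable shift in this assay is available to guide the expectation. Compound 4 is expected to remain at the limit as well, with an estimated step of a number no higher from compound 3 to compound 4 (the limit leaves the size open) that is not resolvable. The estimate for compound 4 in this assay is 30000 nM, within a range of 10000 nM to 100000 nM.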

Compound 4, half-maximal inhibitory concentration: > 30000 nM
Compound 4 ended at the assay's limit; the forecaster's own chance of this, stated with the estimate: 85%; the middle value sits exactly at the limit.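

Neither step into compound 4, from compound 3 or from compound 2, can be read in this assay, as both ends of each are limits: the limit of > 30000 nM in this assay, at which 4 of the 4 values shown sit. On these data alone, whether hydroxymethyl or furan-2-yl changes inhibition on the shared core stays open.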